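The compounds below may be only part of what the source reports. "The series", "measured", "known", "first", "only" and "open" are said of these compounds alone.

Two compounds share a core built from a benzamide joined to a pyridine ring, and both have been tested in an assay on cells for inhibition of MAP kinase-interacting serine/threonine-protein kinase 1 (Homo sapiens), read by mobility shift assay, with stated times of 10 min and 60 min, in the presence of a further agent that is not named here; a lower number here means a stronger inhibitor, a higher number a weaker inhibitor. Compound 1, `Cc1cc(-c2cccnc2)ccc1C(N)=O`, carries a methyl group on the benzamide ring, and in this assay compound 1 gives 22000 nM. Compound 2, `Cc1ncccc1-c1ccc(C(N)=O)cc1`, carries its methyl group on the pyridine ring instead, and in this assay compound 2 gives 170000 nM. Of these two numbers, compound 1 has the lower one, so it is the stronger inhibitor of the pair, and the gap to compound 2 lies beyond the usual scatter of the assay.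

Compound 3, `NC(=O)c1ccc(-c2cccnc2)cc1O`, has not yet been measured. It differs from compound 1 in one place: hydroxy in place of methyl on an aromatic carbon. For the measured compounds named here, no measured pair in this set shows the same swap, so the size of the step can only be guessed. The expectation is a modest change, with the step of a 1.8-fold lower number from compound 1 to compound 3 (0.26 log units; within the scatter) pointing toward a somewhat stronger inhibitor. On that basis compound 3 is estimated to give about 12000 nM in this assay, with a plausible range from 2500 nM to 60000 nM.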

Compound 3, half-maximal inhibitory concentration: 4300 nM
For compound 3 the middle estimate is 2.8-fold (0.45 log units) above the measured one; the measured number falls inside the stated range.
By their numbers in this assay, from the lowest: compound 3; then compound 1; then compound 2.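

The carbon ortho to a carbamoyl group is a place where the choice of group clearly matters: replacing methyl with hydroxy there in this assay gives a 5.1-fold lower number from compound 1 to compound 3 (0.71 log units; beyond the scatter). This is the first change at a single place among the compounds shown, so it is the first direct reading of this position, and it shows that the group with one hydrogen-bond donor and one hydrogen-bond acceptor gives the stronger inhibitor here, whereas methyl has neither. Nothing available explains why the number moves this way, so the link between those counts and the step remains only an observation.

This single swap cannot show whether the improvement belongs to hydroxy in particular or would also appear with another group on the same carbon, such as an amine, a methoxy group or a fluorine atom. The compounds shown also leave open how a plain hydrogen at this position would compare, and whether hydroxy in place of methyl would lower the number in the same way elsewhere on the shared core.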